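Series notes: a side-chain ketone enters at compound 4

The source may hold more compounds than are shown below. What is called first, only, known or untested is meant among the compounds shown, and "the series" means these compounds.

Of the compounds shown here, three have been measured in a functional assay on A549 cells (Homo sapiens) for cytotoxicity, read by crystal violet staining, with a stated time of 72 h; on this read-out lower numbers stand for stronger inhibition and higher numbers for weaker inhibition. Compound 1 `COc1cc(/C=C/C(=O)/C=C(O)/C=C/c2ccc(O[C@H]3C=C(C)[C@@H](O)C[C@@H]3[C@@H](C)CCC=C(C)C)c(OC)c2)ccc1O` gives 30600 nM, compound 2 `COc1cc(/C=C/C(=O)/C=C(O)/C=C/c2ccc(O[C@H]3C[C@H]([C@@H](C)CCC=C(C)C)[C@@H](O)C=C3C)c(OC)c2)ccc1O` gives 61900 nM, and compound 3 `COc1cc(/C=C/C(=O)/C=C(O)/C=C/c2ccc(O[C@]3(C)C=C[C@@H]([C@@H](C)CCC=C(C)C)C[C@@H]3O)c(OC)c2)ccc1O` gives 41400 nM. Compound 3 stands second highest of the three numbers; its distance to compound 1 and to compound 2 lies within the scatter, so no order among the three is claimed. Compound 4 `COc1cc(/C=C/C(=O)/C=C(O)/C=C/c2ccc(O[C@]3(C)C=C[C@@H]([C@@H](C)CC(=O)C=C(C)C)C[C@@H]3O)c(OC)c2)ccc1O` is not yet measured. It differs from compound 3 in one place: (2-methylprop-1-en-1-yl)carbonyl in place of 3-methylbut-2-en-1-yl on a saturated chain carbon, two bonds along the chain from a saturated ring carbon. Within the data shown here, no step between two measured compounds is known here, so nothing shows how such a change moves the read-out in this assay. The step of a 1.0-fold lower number from compound 3 to compound 4 (0.01 log units; within the scatter) is expected to stay within the scatter, with no clear direction. Compound 4 is expected to give about 40000 nM, in a range from 15000 nM to 110000 nM.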

Compound 4, half-maximal inhibitory concentration: 15200 nM
Beside the measured number, compound 4's estimate is 2.6-fold (0.42 log units) above it; the range from low to high includes it.
By their numbers in this assay, from the lowest: compounds 4, 1, 3 and 2 (each within the scatter of the next, the first and the last beyond it).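

In this assay the change to (2-methylprop-1-en-1-yl)carbonyl from 3-methylbut-2-en-1-yl gives a 2.7-fold lower number from compound 3 to compound 4 (0.44 log units; beyond the scatter) on this side chain. Among these compounds, the earlier compounds offered no step at all, so this is the first sign that the read-out responds to a change at this position, though the size is modest. No measurement on hand bears on why the number moves.

Open: whether a hydroxyl or an amine in place of the carbonyl, or a longer chain, moves the number the same way. Going by these compounds, also open: whether the same change carries over to the cores of compound 1 and compound 2.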